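A Third Aryl Group on a Shared Core

The source may report more compounds than this note shows. Statements on the series, on what has been measured and on what is new or still open speak of the compounds shown alone.

compound 1 `O=C(Nc1ccc(Oc2ccnc3[nH]ccc23)cc1)c1cc2cccnc2n(-c2ccc(F)cc2)c1=O` – 160 nM
compound 2 `O=C(Nc1ccc(Oc2ccnc3[nH]ccc23)cc1)c1cc2cccnc2n(-c2ccc(Br)cc2)c1=O` – 270 nM

In a functional assay on HT-29 cells (Homo sapiens) for antiproliferative activity, read by MTT assay, with a stated time of 72 h (a higher number here means a weaker inhibitor, a lower number a stronger inhibitor), compound 1 gives 160 nM and compound 2 gives 270 nM. Among the compounds with values here, compound 2 carries the higher of the two numbers, with compound 1 as its only neighbour. Within the data shown here, the sole measured step, a 1.7-fold higher number from compound 1 to compound 2 (0.23 log units; within the scatter), is within the scatter. Compound 3 `O=C(Nc1ccc(Oc2ccnc3[nH]ccc23)cc1)c1cc2cccnc2n(-c2ccc(C(F)(F)F)cc2Cl)c1=O` differs from compound 2 by 2-chloro-4-(trifluoromethyl)phenyl in place of 4-bromophenyl on an aromatic nitrogen. Among the measured compounds shown here, only that one small step bears on this change, and no measured compound carries a second substituent on this phenyl ring, so little movement is expected. Compound 3 is therefore estimated at 300 nM in this assay, between 100 nM and 900 nM. The expected step of a 1.1-fold higher number from compound 2 to compound 3 (0.05 log units; within the scatter) is thus not beyond the scatter.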

Compound 3, half-maximal inhibitory concentration: 2160 nM
Compound 3: middle estimate off by 7.2-fold (0.86 log units), on the low side, and the stated range ends below it.
By their numbers in this assay, from the lowest: compounds 1 and 2 (each within the scatter of the next); then compound 3.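

In this assay, the aryl group on the aromatic nitrogen proves able to move the number beyond the scatter, which the bromo-for-fluoro change had not shown: 2-chloro-4-(trifluoromethyl)phenyl gives an 8.0-fold higher number from compound 2 to compound 3 (0.90 log units; beyond the scatter) and a 14-fold higher number from compound 1 to compound 3 (1.13 log units; beyond the scatter). This change brings in two new substituents at once, so the step cannot be divided between them. No measurement at hand gives a cause for it.

Still open, as far as these compounds go, is whether 2-chlorophenyl or 4-(trifluoromethyl)phenyl alone would carry the step. Also open, from the compounds shown here alone, is how a methoxy group or an amine on this phenyl ring would read.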